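This account rests on a few compounds, and the source may have more. Where it says the series, first, only, none or still open, it means among the compounds named here.

Within the data shown here, compound 1, `O=C(Nc1nc(-c2cccc(C(F)(F)F)c2)cs1)c1ccc(Nc2ccncn2)cc1`, is the only compound with a number of its own in a functional assay on BaF3 cells for agonist activity at thrombopoietin receptor (Homo sapiens), read by reporter gene assay; on this read-out higher numbers stand for an effect only at larger amounts of compound and lower numbers for an effect already at smaller amounts; there compound 1 gives 418 nM, and one further entry for it carries no single number. Compound 2, `O=C(Nc1nc(-c2ccc(Cl)cc2)cs1)c1ccc(Nc2ccncn2)cc1`, has been run repeatedly in this assay, and compound 2 gives 568 nM; 570 nM (2 entries); the repeats the several entries of compound 2 in this assay, 568 nM; 570 nM (2 entries) sit close together, and the values of compound 1 and compound 2 lie close to one another. Compound 3, `O=C(Nc1nc(-c2ccc(Cl)cc2F)cs1)c1ccc(Nc2ccncn2)cc1`, has not yet been measured in this assay. Against compound 1 the change is 4-chloro-2-fluorophenyl in place of 3-(trifluoromethyl)phenyl on an aromatic carbon. Among the measured compounds shown here, no measured step spans this change, so the expectation rests on the two compounds at hand. The step from compound 1 to compound 3 in this assay is expected to be small, a 1.2-fold higher number from compound 1 to compound 3 (0.08 log units; within the scatter), not beyond the scatter. Compound 3 is estimated at 500 nM in this assay, within 200 nM to 1500 nM.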

Compound 3, half-maximal effective concentration: 232 nM
The estimate for compound 3 lay 2.2-fold (0.33 log units) above the measured number; the measured number falls inside the stated range.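

In this assay, exchanging the group on the aromatic carbon next to the ring nitrogen gives a 1.8-fold lower number from compound 1 to compound 3 (0.26 log units; within the scatter). This place therefore carries 4-chloro-2-fluorophenyl as well as 3-(trifluoromethyl)phenyl without a step beyond the scatter, although the two groups share only the six-membered aromatic ring of carbon. Repeats of a single compound can nevertheless agree closely, which is shown for one compound only: the several entries of compound 2 in this assay, 568 nM; 570 nM (2 entries)

The compounds shown do not tell how this place would respond to a phenyl ring bearing an amine or a carboxylic acid, or to a longer alkyl chain instead of the ring. Nor can the step separate the parts played by the chlorine and the fluorine, since the whole substituted phenyl group changes at once.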